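The source may report more compounds than this note shows. Statements on the series, on what has been measured and on what is new or still open speak of the compounds shown alone.

Measured compounds in an assay on HEK293 cells for inhibition of neurogenic locus notch homolog protein 1 (Homo sapiens), read by a luciferase reporter and resazurin assay, with a stated time of 16 h; on this read-out higher numbers stand for weaker inhibition and lower numbers for stronger inhibition:
- compound 1 `CC1=C(C(=O)OCC2CCN(C(=O)OC(C)(C)C)CC2)C(c2cccc([N+](=O)[O-])c2)C2=C(CC(C)(C)CC2=O)N1`, reported only as a limit, > 10000 nM
- compound 2 `CC1=C(C(=O)OCC2CCN(C(=O)OC(C)(C)C)CC2)C(c2cccc(C(C)C)c2)C2=C(CC(C)(C)CC2=O)N1`, 3320 nM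
- compound 3 `CC1=C(C(=O)OCC2CCN(C(=O)OC(C)(C)C)CC2)C(c2cccc(C(F)(F)F)c2)C2=C(CC(C)(C)CC2=O)N1`, 760 nM

Compound 3 holds the lowest of the two numbers in this assay; its nearest neighbour is compound 2, separated by a 4.4-fold lower number from compound 2 to compound 3 (0.64 log units; beyond the scatter). Compound 4 `CC1=C(C(=O)OCC2CCN(C(=O)OC(C)(C)C)CC2)C(c2cccc(-c3ccc4[nH]ccc4c3)c2)C2=C(CC(C)(C)CC2=O)N1` differs from compound 3 by 1H-indol-5-yl in place of trifluoromethyl on an aromatic carbon. The steps measured so far all exchange one small substituent for another at that same aromatic carbon: an at least 3.0-fold lower number from compound 1 to compound 2 (0.47 log units; beyond the scatter), an at least 13-fold lower number from compound 1 to compound 3 (1.11 log units; beyond the scatter) and a 4.4-fold lower number from compound 2 to compound 3 (0.64 log units; beyond the scatter). None of them brings in a ring system, so they bear only loosely on this change. Compound 4 is therefore expected to land near compound 3 with wide uncertainty, estimated at 1500 nM (range 300 nM to 8000 nM), a step of a 2.0-fold higher number from compound 3 to compound 4 (0.30 log units; within the scatter).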

Compound 4, half-maximal inhibitory concentration: 770 nM
Compound 4: middle estimate off by 1.9-fold (0.29 log units), on the high side; low and high end bracket the measured number.
By their numbers in this assay, from the lowest: compounds 3 and 4 (each within the scatter of the next); then compound 2. At a limit, above all of these: compound 1.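

At this aromatic carbon, this assay accepts a ring system as readily as a small group: 1H-indol-5-yl in place of trifluoromethyl gives a 1.0-fold higher number from compound 3 to compound 4 (0.01 log units; within the scatter). The same ring system set against isopropyl gives a 4.3-fold lower number from compound 2 to compound 4 (0.63 log units; beyond the scatter), so bringing in more heavy atoms does not by itself raise the number here. Against nitro it gives an at least 12-fold lower number from compound 1 to compound 4 (1.11 log units; beyond the scatter), a step that rests on a limit and not on a number: the limit of > 10000 nM in this assay, at which 1 of the 4 values shown sits.

Going by these compounds, whether 1H-indol-5-yl depends on its hydrogen-bond donor stays open. On these data alone, how an amine or a carboxylic acid at this carbon would read also stays open.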